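The compounds below may be only part of what the source reports. "The series", "measured", "known", "first", "only" and "open" are said of these compounds alone.

Measured so far:
In a functional assay on T47D cells (Homo sapiens) for antiproliferative activity, read by MTT assay, with a stated time of 72 h (a lower number here means a stronger inhibitor, a higher number a weaker inhibitor), compound 1 `CS(=O)(=O)c1ccc(C(=O)Nc2ccc(Cl)c(-c3nnc4c(Cl)cccn34)c2)cc1` gives > 100000 nM, which is a limit of the assay.
Compound 2 `O=C(Nc1ccc(Cl)c(-c2nnc3c(Cl)cccn23)c1)c1ccc(Cl)cc1Cl` gives > 100000 nM in this assay, again a limit.
Compound 3 `CS(=O)(=O)c1ccc(C(=O)Nc2ccc(Cl)c(-c3nnc4c(Cl)cccn34)c2)c(Cl)c1` gives > 100000 nM in this assay, also a limit.

Compound 3 therefore stands nowhere on a scale of numbers: all three values sit at the limit of > 100000 nM in this assay, at which 3 of the 3 values shown sit, and compound 3 is not distinguished from the other two. Compound 4 `O=C(Nc1ccc(Cl)c(-c2nnc3c(Cl)cccn23)c1)c1ccccc1Cl` differs from compound 3 by hydrogen in place of methylsulfonyl on an aromatic carbon. The measured steps that touch this position are a step that the two limits leave unreadable from compound 2 to compound 3 and, at the same ring, a step that the two limits leave unreadable from compound 1 to compound 3, and the remaining comparison, a step that the two limits leave unreadable from compound 1 to compound 2, is equally silent; none of them has a readable size, so no direction can be taken from them. Since the replacement of methylsulfonyl by chloro in compound 2 did not bring any value into the readable range, the removal of methylsulfonyl is not expected to do so either. Compound 4 is expected to give 150000 nM, within 50000 nM to 500000 nM, most likely reported again as a limit. The step this implies is an expected step that the limit leaves unreadable from compound 3 to compound 4.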

Compound 4, half-maximal inhibitory concentration: 83800 nM
For compound 4 the middle estimate is 1.8-fold (0.25 log units) above the measured one, within the range that was stated.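

In this assay, among the compounds shown here, compound 4, with hydrogen on this aromatic carbon, gives 83800 nM, the first value that is a number and not a limit. The change can be read only as floors: an at least 1.1-fold lower number from compound 3 to compound 4 (0.07 log units; that floor lies within the scatter), an at least 1.1-fold lower number from compound 2 to compound 4 (0.07 log units; that floor lies within the scatter) and an at least 1.1-fold lower number from compound 1 to compound 4 (0.07 log units; that floor lies within the scatter), so hydrogen here brings a value into the readable range, but no step is shown to go beyond the scatter. The steps among compound 1, compound 2 and compound 3 still cannot be read, and these three compounds stay at the assay's limit: the limit of > 100000 nM in this assay, at which 3 of the 4 values shown sit.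

As far as these compounds go, how far compound 4 truly lies from the other three remains open, as their real values are unknown. Also open, from the compounds shown here alone, is what an amine or a carboxylic acid on this aromatic carbon would give.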